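Methoxy in Place of Chloro on a Phenoxy Ring

This account rests on a few compounds, and the source may have more. Where it says the series, first, only, none or still open, it means among the compounds named here.

Compound 1 `CCc1nn(C)c(CO/N=C/c2c(C)nn(C)c2Oc2ccc(F)cc2)c1Cl` is reported in a functional assay on SMMC-7721 cells (Homo sapiens) for inhibition, read by MTT assay, with a stated time of 72 h, tested at 25 uM (on this read-out higher numbers stand for more inhibition at the one concentration tested (going by the name of the read-out) and lower numbers for less inhibition), as < 80%, a limit of the assay.
Compound 2 `Cc1nn(C)c(Oc2ccc(Cl)cc2)c1/C=N\OCc1c(Cl)c(-c2ccc(F)cc2)nn1C` gives 80% in this assay.
Compound 3 `CCc1nn(C)c(CO/N=C/c2c(C)nn(C)c2Oc2ccccc2Cl)c1Cl` is reported in this assay as < 80%, again a limit.

Among the measured compounds shown here, compound 2 thus stands as the only number in this assay; the other two values are limits, as the limit of < 80% in this assay, at which 2 of the 3 values shown sit, records. For the measured compounds named here, the one measured step, a step that the two limits leave unreadable from compound 1 to compound 3, cannot be read from the two limits and does not touch the change now made. Compound 4 `COc1ccc(Oc2c(/C=N\OCc3c(Cl)c(-c4ccc(F)cc4)nn3C)c(C)nn2C)cc1` differs from compound 2 by methoxy in place of chloro on an aromatic carbon. Going by the values given here, no measured step bears on this exchange, so no step beyond the scatter is expected in this assay in either direction. Compound 4 is therefore estimated at 75%, in the range 55% to 90%, the expected step being a number 5 percentage points lower from compound 2 to compound 4 (within the scatter).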

Compound 4, a percentage reported as inhibition, at one concentration (the size of the read-out at that concentration, not a potency): 80%
The estimate for compound 4 lay 5 percentage points below the measured number; measured number inside the range.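

Methoxy in place of chloro on an aromatic carbon, para to a large group, gives no change at the digits printed from compound 2 to compound 4 (within the scatter) in this assay. This is the first readable step among the compounds shown, and it shows that this position can carry either group with the read-out unchanged at the digits printed. Compound 1 and compound 3 remain limits, and the step between them cannot be read: the limit of < 80% in this assay, at which 2 of the 4 values shown sit.

From the compounds shown here alone, whether an amine or a carboxylic acid in this position would leave the read-out unchanged stays open. Going by these compounds, both numbers are readings at one concentration, so any difference in potency between compound 2 and compound 4 also stays open.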